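Methoxy in Place of Methylsulfanyl: An Expected Small Shift

The source may report more compounds than this note shows. Statements on the series, on what has been measured and on what is new or still open speak of the compounds shown alone.

Of the compounds shown here, three have been tested in a functional assay on HT-29 cells (Homo sapiens) for cytotoxicity, read by MTT assay, with a stated time of 72 h; a higher number here means a weaker inhibitor of growth, a lower number a stronger inhibitor of growth. Compound 2 `CSc1ccc(CNc2nc(SC)nc3ncccc23)cc1` gives 4320 nM, the lowest of the three numbers. Compound 3 `CSc1ccc(CNc2nc([SeH])nc3ccccc23)cc1` gives 42900 nM, and compound 1 `COc1ccc(CNc2nc([Se]C)nc3ccccc23)cc1` gives 73600 nM; both stand beyond the scatter above compound 2. Compounds 1 and 3 differ in more than one place, so their values show only that they lie close together. Compound 4 `COc1ccc(CNc2nc(SC)nc3ncccc23)cc1` is the next compound to be measured in this assay. It differs from compound 2 by methoxy in place of methylsulfanyl on an aromatic carbon, the same kind of group that compound 1 carries. Among the measured compounds shown here, no measured pair isolates this change. The step of a 1.7-fold higher number from compound 2 to compound 4 (0.24 log units; within the scatter) is expected to be a modest weakening, possibly within the scatter. Compound 4 is therefore expected to give 7500 nM, within a range from 2500 nM to 25000 nM.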

Compound 4, concentration for 50% growth inhibition: > 100000 nM
Compound 4: no number, only a limit; the forecaster's own chance of this, stated with the estimate: 2%; at least 13-fold (1.12 log units) between middle value and limit.
By their numbers in this assay, from the lowest: compound 2; then compounds 3 and 1 (each within the scatter of the next). At a limit, above all of these: compound 4.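

On the aromatic carbon para to a large group, methoxy in place of methylsulfanyl is no small change in this assay: the two groups have equal counts of heavy atoms and acceptors, yet the step is an at least 23-fold higher number from compound 2 to compound 4 (1.36 log units; beyond the scatter). Compound 4 gives only a limit, not a number: the limit of > 100000 nM in this assay, at which 1 of the 4 values shown sits. The earlier compounds shown here, which differ in more than one place, could not show that this one swap matters so much.

On these data alone, how far past that limit compound 4 lies remains open, so the full size of the step is unknown. As far as these compounds go, whether an amine or a longer chain such as ethylsulfanyl at this position would match compound 2 also remains open.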